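Removing one methyl from the core of a chalcone

This account rests on a few compounds, and the source may have more. Where it says the series, first, only, none or still open, it means among the compounds named here.

Measured so far:
compound 1 `COc1cccc(/C=C/C(=O)c2c(OC)cc(OC)cc2OC)c1`, 12%
compound 2 `COc1cc(OC)c(C(=O)/C=C/c2ccc(F)cc2)c(OC)c1`, 10%

In a functional assay on MDA-MB-231 cells (Homo sapiens), read by fluorescence and BrdU incorporation, with a stated time of 48 h, tested at 25 uM (on this read-out higher numbers stand for a weaker effect at the one concentration tested and lower numbers for a stronger effect), compound 1 gives 12%. Within the data shown here, compound 1 holds the highest of the two numbers, but the only neighbour, compound 2, differs by a number 2 percentage points lower from compound 1 to compound 2 (within the scatter), a gap within the scatter, so the two compounds cannot be told apart on this read-out.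

Compound 3 `COc1cccc(/C=C/C(=O)c2c(O)cc(OC)cc2OC)c1` keeps the core of compound 1 and differs from it only by hydrogen in place of methyl on an oxygen on an aromatic ring. Among the measured compounds shown here, no measured step touches this oxygen: the one step available, a number 2 percentage points lower from compound 1 to compound 2 (within the scatter), changes the other ring and was within the scatter. No guidance therefore exists for the size or direction of the move in this assay, and the working expectation is a step of a number 3 percentage points higher from compound 1 to compound 3 (within the scatter), nothing beyond the scatter. Compound 3 is estimated to give 15%, expected between 5% and 40%.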

Compound 3, a percentage reported as activity, at one concentration (the size of the read-out at that concentration, not a potency): 38%
Compound 3: the middle estimate sits 23 percentage points below what was measured; measured number inside the range.
By their numbers in this assay, from the lowest: compounds 2 and 1 (each within the scatter of the next); then compound 3.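

The change from methoxy to hydroxy gives a number 26 percentage points higher from compound 1 to compound 3 (beyond the scatter) in this assay and so marks this oxygen on an aromatic ring as a place where removing one methyl weakens the effect at the one concentration tested. The only earlier step changed the other ring and stayed within the scatter, which makes this the first change shown to move the read-out beyond it. No measurement at hand explains why this small edit has such an effect.

From the compounds shown here alone, whether an ethoxy group, with its longer chain, or an amine at this place would weaken the effect as the hydroxy does remains open. So does whether the same swap at the other methoxy groups of the shared core would give a similar step.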